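The source may hold more compounds than are shown below. What is called first, only, known or untested is meant among the compounds shown, and "the series" means these compounds.

Working notes on the series.

Two compounds have numbers in an assay on HEK293 cells for displacement of a labelled ligand from growth hormone secretagogue receptor type 1 (Homo sapiens), with a stated time of 60 min (on this read-out lower numbers stand for stronger inhibition and higher numbers for weaker inhibition), so far. Compound 1 `CN1CCC(S(=O)(=O)c2ccc3nc(NC(=O)NC(=O)c4cc(N5CCCC5)c(C#N)cc4Cl)sc3c2)CC1` gives 0.4 nM in this assay. Compound 2 `CN1CCN(CCCS(=O)(=O)c2ccc3nc(NC(=O)NC(=O)c4cc(N5CCCC5)ccc4Cl)sc3c2)CC1` gives 0.29 nM in this assay. Compound 2 stands at the lower of the two numbers, with compound 1 the nearest at a gap that is within the scatter; the two values therefore read as level. For the measured compounds named here, compounds 1 and 2 differ in more than one place, so no single step between them is on hand.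

Compound 3 `CN1CCN(CCCS(=O)(=O)c2ccc3nc(NC(=O)NC(=O)c4cc(N5CCCC5)c(C#N)cc4Cl)sc3c2)CC1` is not yet measured in this assay. It differs from compound 2 in a single place: cyano in place of hydrogen on an aromatic carbon. Compound 1 carries the same cyano group on the same ring of the shared core, and its number in this assay sits within the scatter of that of compound 2. On that basis the step is expected to be small, with no direction beyond the scatter, and the estimated step of a 1.0-fold higher number from compound 2 to compound 3 (0.01 log units; within the scatter) reflects this. For compound 3 the expected value in this assay is 0.3 nM, with a range from 0.1 nM to 1 nM.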

Compound 3, half-maximal inhibitory concentration: 0.24 nM
The estimate for compound 3 lay 1.3-fold (0.10 log units) above the measured number, within the range that was stated.
By their numbers in this assay, from the lowest: compounds 3, 2 and 1 (each within the scatter of the next).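

In this assay, for the compounds shown here, cyano in place of hydrogen on the aromatic carbon ortho to the pyrrolidin-1-yl group and meta to the chloro group gives a 1.2-fold lower number from compound 2 to compound 3 (0.08 log units; within the scatter) and so reads as level; this is the first single-place comparison at this position, which compounds 1 and 2 could not provide. Going by these compounds alone, with that cyano group held constant, 3-(4-methylpiperazin-1-yl)propyl in place of 1-methylpiperidin-4-yl on the sulfonyl sulfur gives a 1.7-fold lower number from compound 1 to compound 3 (0.22 log units; within the scatter) and so also reads as level, the first single-place comparison of these two groups. No measurement on hand bears on why either step is this small.

Whether this aromatic carbon would stay level with a methoxy group, an amine or a carboxylic acid in place of cyano remains an open question. Also open, going by these compounds, is how the number would respond on the sulfonyl sulfur to a longer chain than the propyl of compound 3, or to a morpholine in place of its 4-methylpiperazin-1-yl group.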